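Methoxy in Place of Dimethylamino on the Aryl Group

The source may report more compounds than this note shows. Statements on the series, on what has been measured and on what is new or still open speak of the compounds shown alone.

Three measured compounds share one core and differ only in the aryl group sitting on a carbonyl carbon. Compound 1 `Cc1cc(C)cc(C(=O)N(CCC(=O)NCc2ccccc2)Cc2ccc(C(=O)NO)cc2)c1` gives 20.5 nM in an assay on Sf9 cells for inhibition of protein deacetylase HDAC6 (Homo sapiens), read by fluorescence, with stated times of 90 min and 30 min (a lower number here means a stronger inhibitor, a higher number a weaker inhibitor), compound 2 `O=C(CCN(Cc1ccc(C(=O)NO)cc1)C(=O)c1ccccc1)NCc1ccccc1` gives 12.5 nM, and compound 3 `CN(C)c1ccc(C(=O)N(CCC(=O)NCc2ccccc2)Cc2ccc(C(=O)NO)cc2)cc1` gives 14.8 nM, the second highest of the three numbers, though all three lie within the scatter of one another. Compound 4 `COc1ccc(C(=O)N(CCC(=O)NCc2ccccc2)Cc2ccc(C(=O)NO)cc2)cc1` carries methoxy in place of dimethylamino on an aromatic carbon. The steps already seen on this aryl group, a 1.2-fold higher number from compound 2 to compound 3 (0.07 log units; within the scatter), a 1.4-fold lower number from compound 1 to compound 3 (0.14 log units; within the scatter) and a 1.6-fold lower number from compound 1 to compound 2 (0.21 log units; within the scatter), all stayed within the scatter, so no step beyond the scatter is expected in this assay here either. Compound 4 is therefore estimated at 15 nM, with a range from 6 nM to 38 nM. That amounts to an expected step of a 1.0-fold higher number from compound 3 to compound 4 (0.01 log units; within the scatter).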

Compound 4, half-maximal inhibitory concentration: 25.3 nM
The estimate for compound 4 lay 1.7-fold (0.23 log units) below the measured number, within the range that was stated.
By their numbers in this assay, from the lowest: compounds 2, 3, 1 and 4 (each within the scatter of the next, the first and the last beyond it).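

In this assay, among the compounds shown here, methoxy gives the first step on this aryl group that lies beyond the scatter, though only a modest one, with methoxy in place of hydrogen (a 2.0-fold higher number from compound 2 to compound 4 (0.31 log units; beyond the scatter)). Methoxy in place of dimethylamino (a 1.7-fold higher number from compound 3 to compound 4 (0.23 log units; within the scatter)) and 4-methoxyphenyl in place of 3,5-dimethylphenyl (a 1.2-fold higher number from compound 1 to compound 4 (0.09 log units; within the scatter)) both stay within the scatter, so these three aryl groups cannot be told apart here. No measurement shown accounts for the step from hydrogen to methoxy. Still open, from the compounds shown here alone, is how a primary amine or a carboxylic acid on the same aromatic carbon would read in this assay.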